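The source may hold more compounds than are shown below. What is called first, only, known or untested is meant among the compounds shown, and "the series" means these compounds.

Of the compounds shown here, three of one series have been measured in a physicochemical assay for solubility; a lower number here means a less soluble compound, a higher number a more soluble compound. Compound 1 `COc1cc2cc(C(=O)CCC3CC[N+](C)(Cc4ccccc4)CC3)sc2cc1OC` gives 2000 ug/mL in this assay. Compound 2 `COc1cc2cc(C(=O)CC3=CC[N+](C)(Cc4ccccc4)CC3)sc2cc1OC` gives 20000 ug/mL in this assay. Compound 3 `C=CC[n+]1ccc(CCC(=O)c2cc3cc(OC)c(OC)cc3s2)cc1` gives 25000 ug/mL in this assay. Among these three numbers compound 3 holds the highest, but its nearest neighbour, compound 2, sits within the usual scatter of it, so the two cannot be told apart; only compound 1 lies beyond the scatter, with the lower value.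

Compound 4 `COCC[n+]1ccc(CCC(=O)c2cc3cc(OC)c(OC)cc3s2)cc1` is not yet measured. It differs from compound 3 in one place: methoxymethyl in place of vinyl on a saturated chain carbon bound to an aromatic nitrogen. For the measured compounds named here, no measured pair in this set shows the same change, so no step can be carried over from the data.

Given that the shared core and the charged ring are untouched, and the change is confined to a short chain, the expected step from compound 3 to compound 4 in this assay is a 1.1-fold higher number from compound 3 to compound 4 (0.03 log units; within the scatter), which is not expected to exceed the scatter in either direction. Compound 4 is therefore estimated at 27000 ug/mL in this assay, within a range from 13000 ug/mL to 55000 ug/mL.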

Compound 4, solubility: 33000 ug/mL
Compound 4: the middle estimate sits 1.2-fold (0.09 log units) below what was measured; the measured number falls inside the stated range.
By their numbers in this assay, from the lowest: compound 1; then compounds 2, 3 and 4 (each within the scatter of the next).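

Placed on a saturated chain carbon bound to an aromatic nitrogen, methoxymethyl in place of vinyl gives in this assay a 1.3-fold higher number from compound 3 to compound 4 (0.12 log units; within the scatter) and this is the only step in the set that links two compounds differing in one place. The exchange brings in an oxygen and a hydrogen-bond acceptor and removes a double bond outside aromatic rings, yet compound 3 and compound 4 cannot be told apart by their numbers, so at this position these differences in the chain come with no step beyond the scatter. Nothing measured here offers an explanation for this outcome.

Going by these compounds, whether an amine, a carboxylic acid or a longer chain at the same position would also remain within the scatter of compound 3 is still open. For the compounds shown here, a single step also cannot show whether the same exchange would read alike on another charged ring, such as the one in compound 1, since that compound does not carry this chain.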